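From a Diethylamino Chain to a Methylpiperidinyl Ring

The source may report more compounds than this note shows. Statements on the series, on what has been measured and on what is new or still open speak of the compounds shown alone.

Measured so far:
Compound 1 `CCN(CC)CCCOc1ccc(Nc2nccc(-c3ccncc3)n2)cc1` — 1300 nM
Compound 2 `COc1cccc(Nc2nccc(-c3ccco3)n2)c1` — 400 nM
Compound 3 `CC1CCN(C(=O)COc2ccc(Nc3nccc(-c4ccncc4)n3)cc2)CC1` — 300 nM

All three were tested in a functional assay for inhibition, with Homo sapiens as the target; a higher number here means a weaker inhibitor, a lower number a stronger inhibitor. Compound 1 gives the highest number of the three: compound 2 sits lower by a margin beyond the scatter, and compound 3 lower still. Compound 4 `CC1CCN(c2ccc(Nc3nccc(-c4ccncc4)n3)cc2)CC1` is the next compound to be measured. It differs from compound 1 at one place: 4-methylpiperidin-1-yl in place of 3-(diethylamino)propoxy on an aromatic carbon. Going by the values given here, the one measured step that bears on this is a 4.3-fold lower number from compound 1 to compound 3 (0.64 log units; beyond the scatter), where the same 4-methylpiperidin-1-yl ring arrived, though still joined through a carbonyl and the oxygen-bound chain. Compound 4 carries that ring directly on the aromatic carbon and drops the chain altogether. On this single precedent a modest lowering is expected, a 2.6-fold lower number from compound 1 to compound 4 (0.41 log units; beyond the scatter), and compound 4 is estimated at 500 nM, within 200 nM to 1500 nM.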

Compound 4, half-maximal inhibitory concentration: 600 nM
The estimate for compound 4 lay 1.2-fold (0.08 log units) below the measured number, and the stated range covers the measured number.
By their numbers in this assay, from the lowest: compounds 3, 2 and 4 (each within the scatter of the next); then compound 1.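

In this assay, the 3-(diethylamino)propoxy chain proves dispensable at this aromatic carbon: with 4-methylpiperidin-1-yl bound directly in its place, there is a 2.2-fold lower number from compound 1 to compound 4 (0.34 log units; beyond the scatter). Until now, that ring had been seen only at the end of a carbonyl and an oxygen-bound chain, so the result shows that it can stand on the aromatic carbon without either. No available evidence accounts for the step.

The compounds shown leave open whether the ring itself matters or only the loss of the chain. A morpholine or a piperazine at this carbon would help separate the two.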